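This account rests on a few compounds, and the source may have more. Where it says the series, first, only, none or still open, it means among the compounds named here.

Measured compounds and their results in a functional assay on HeLa cells (Homo sapiens) for cytotoxicity, read by MTT assay, with a stated time of 72 h; on this read-out lower numbers stand for stronger inhibition and higher numbers for weaker inhibition:

- compound 1, `Cc1cc(-c2ccccc2)n(/C(N)=N/S(=O)(=O)c2cc(C)c(Cl)cc2SCc2cccc(C(F)(F)F)c2)n1`, 98000 nM
- compound 2, `Cc1cc(-c2ccccc2)n(/C(N)=N/S(=O)(=O)c2cc(C)c(Cl)cc2SCc2ccccc2C)n1`, 160000 nM
- compound 3, `Cc1cc(S(=O)(=O)/N=C(\N)n2nccc2-c2ccccc2)c(SCc2ccccc2C)cc1Cl`, 17000 nM

Compound 3 stands lowest of the three in this assay, beyond the scatter from both compound 1 and compound 2. The cores of compound 2 and compound 3 differ by hydrogen in place of methyl on an aromatic carbon, and that change gave a 9.4-fold lower number from compound 2 to compound 3 (0.97 log units; beyond the scatter).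

Compound 4, `Cc1cc(S(=O)(=O)/N=C(\N)n2nccc2-c2ccccc2)c(SCc2cccc(C(F)(F)F)c2)cc1Cl`, is not yet measured. It differs from compound 3 by 3-(trifluoromethyl)phenyl in place of 2-methylphenyl on a saturated chain carbon bound to a sulfur. The same change, at the same place, has already been made once in the series, from compound 2 to compound 1, where it gave a 1.6-fold lower number from compound 2 to compound 1 (0.21 log units; within the scatter), a step that does not rise above the usual scatter. For the measured compounds named here, only this one precedent exists, and it sits on the methyl-bearing core rather than on the core of compound 3.

On that basis the step from compound 3 to compound 4 in this assay is expected to be small, a 1.3-fold lower number from compound 3 to compound 4 (0.12 log units; within the scatter), resting on a 1.6-fold lower number from compound 2 to compound 1 (0.21 log units; within the scatter). Compound 4 is accordingly estimated at 13000 nM, with a likely range of 5000 nM to 35000 nM.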

Compound 4, half-maximal inhibitory concentration: 19000 nM
Beside the measured number, compound 4's estimate is 1.5-fold (0.16 log units) below it; measured number inside the range.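

In this assay, 3-(trifluoromethyl)phenyl in place of 2-methylphenyl on a saturated chain carbon bound to a sulfur gives a 1.1-fold higher number from compound 3 to compound 4 (0.05 log units; within the scatter), and its two readings agree: the same change on two cores in this assay, a 1.6-fold lower number (0.21 log units; within the scatter) from compound 2 to compound 1 and a 1.1-fold higher number (0.05 log units; within the scatter) from compound 3 to compound 4, 1.8-fold (0.26 log units) apart, within the scatter of two such steps. Hydrogen in place of methyl on an aromatic carbon gives a 5.2-fold lower number from compound 1 to compound 4 (0.71 log units; beyond the scatter), so the step beyond the scatter also holds with the new group, and its two readings agree as well: the same change on two cores in this assay, a 9.4-fold lower number (0.97 log units; beyond the scatter) from compound 2 to compound 3 and a 5.2-fold lower number (0.71 log units; beyond the scatter) from compound 1 to compound 4, 1.8-fold (0.26 log units) apart, within the scatter of two such steps. For the compounds shown here, neither change depends detectably on the other across these four compounds, and none of the four goes against that, but the result rests on one pair of cores and one pair of groups, and it shows only that a step within the scatter stays within the scatter, not that larger steps at this place would carry over.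

Open, on these data alone, is whether an amine or a carboxylic acid in place of 3-(trifluoromethyl)phenyl, or a longer chain on the sulfur, would carry over in the same way. Also open, as far as these compounds go, is whether ethyl or methoxy in place of that methyl would give a comparable step.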